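The source may report more compounds than this note shows. Statements on the series, on what has been measured and on what is new or still open speak of the compounds shown alone.

Compound 2 `Fc1ccccc1NC(=S)N/N=C/c1ccc2ccccc2n1` is, in a functional assay on HeLa cells (Homo sapiens) for antiproliferative activity, read by sulforhodamine B assay, with a stated time of 72 h (on this read-out lower numbers stand for stronger inhibition and higher numbers for weaker inhibition), reported only as a limit, > 100000 nM. That limit, (the limit of > 100000 nM in this assay, at which 1 of the 3 values shown sits), marks the edge of what the test can resolve. Among the measured compounds shown here, compound 1 `FC(F)(F)c1ccccc1NC(=S)N/N=C/c1ccc2ccccc2n1` gives 18800 nM in this assay, and the step of an at least 5.3-fold higher number from compound 1 to compound 2 (0.72 log units; beyond the scatter) is the single measured change among the three compounds. Compound 3 `NC(=S)N/N=C/c1cc2cccnc2s1`, built on a different core, gives 6290 nM. Compound 4 `N#Cc1ccc(NC(=S)N/N=C/c2ccc3ccccc3n2)cc1` arises from compound 2 by 4-cyanophenyl in place of 2-fluorophenyl on an amide-type nitrogen, a change on the same ring but not covered by any measured step. With compound 2 at a limit and compound 1 some way below it, a move to compound 4 of an at least 3.3-fold lower number from compound 2 to compound 4 (0.52 log units; beyond the scatter) is expected, with wide uncertainty. Compound 4 is estimated at 30000 nM, between 8000 nM and 100000 nM.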

Compound 4, half-maximal inhibitory concentration: 20000 nM
The estimate for compound 4 lay 1.5-fold (0.18 log units) above the measured number; the measured number falls inside the stated range.
By their numbers in this assay, from the lowest: compound 3; then compounds 1 and 4 (each within the scatter of the next). At a limit, above all of these: compound 2.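

Replacing 2-fluorophenyl with 4-cyanophenyl on the amide-type nitrogen gives an at least 5.0-fold lower number from compound 2 to compound 4 (0.69 log units; beyond the scatter), so this position can bring the number back within the range the test can read. From the compounds shown here alone, compound 2 is reported only as a limit, so the true size of this step remains unknown. Compounds 1 and 4 lie within the scatter of each other, although they carry different groups on this ring.

The group and its place on the ring change together here, so neither can be credited alone. Going by these compounds, whether an amine or a carboxylic acid on this ring would give a lower number remains open.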